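The source may hold more compounds than are shown below. What is called first, only, known or untested is meant among the compounds shown, and "the series" means these compounds.

Two ureas and one untested relative share a core in which an aryl ether carries a urea at one end and a basic side chain at the other. Going by the values given here, compound 2 `CN(C)CCCn1cnnc1-c1cc(Oc2ccc(NC(=O)Nc3ccc(Cl)c(C(F)(F)F)c3)cc2F)ccn1` bears a 4-chloro-3-(trifluoromethyl)phenyl on the urea nitrogen, and in a functional assay on NCI-H460 cells (Homo sapiens) for antiproliferative activity, read by MTT assay, with a stated time of 72 h (on this read-out lower numbers stand for stronger inhibition and higher numbers for weaker inhibition), compound 2 gives 1680 nM, the only number among the values shown. Compound 1 `CCN(CC)CCn1cnnc1-c1cc(Oc2ccc(NC(=O)Nc3ccccc3C(F)(F)F)cc2F)ccn1` carries 2-(trifluoromethyl)phenyl on the urea nitrogen and a different side chain on the shared core. In this assay compound 1 gives > 50000 nM, which is a limit of the assay rather than a number, the one at the limit of > 50000 nM in this assay, at which 1 of the 2 values shown sits. Compound 3 `CN(C)CCCn1cnnc1-c1cc(Oc2ccc(NC(=O)Nc3ccccc3C(F)(F)F)cc2F)ccn1` keeps the side chain of compound 2 and differs from it in one place: 2-(trifluoromethyl)phenyl in place of 4-chloro-3-(trifluoromethyl)phenyl on an amide-type nitrogen. Among the compounds with values here, no measured pair differs in this way alone, and compound 1 differs from compound 3 elsewhere on the core, so no single step links them. Still, compound 1 with the same 2-(trifluoromethyl)phenyl reaches only the limit in this assay, so a large loss is expected a 15-fold higher number from compound 2 to compound 3 (1.17 log units; beyond the scatter). Compound 3 is therefore estimated at 25000 nM, between 6000 nM and 50000 nM.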

Compound 3, half-maximal inhibitory concentration: 10900 nM
The estimate for compound 3 lay 2.3-fold (0.36 log units) above the measured number; the range from low to high includes it.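

In this assay, the exchange of 4-chloro-3-(trifluoromethyl)phenyl for 2-(trifluoromethyl)phenyl on the amide-type nitrogen now has a measured size, giving a 6.5-fold higher number from compound 2 to compound 3 (0.81 log units; beyond the scatter) on an unchanged side chain. With 2-(trifluoromethyl)phenyl held fixed, the side chain also matters: (dimethylamino)methyl in place of diethylamino on a saturated chain carbon, two bonds along the chain from an aromatic nitrogen, gives an at least 4.5-fold lower number from compound 1 to compound 3 (0.66 log units; beyond the scatter) as the step. That step is only a lower bound, since compound 1 stands at a limit of the assay and not at a number: the limit of > 50000 nM in this assay, at which 1 of the 3 values shown sits.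

The two aryl groups differ in both the chlorine and the placement of the trifluoromethyl, so it stays open which of these accounts for the step, a question that 4-chlorophenyl or 3-(trifluoromethyl)phenyl on the same nitrogen would address. As far as these compounds go, it is also open whether the side-chain step holds with 4-chloro-3-(trifluoromethyl)phenyl on the urea, and how a pyrrolidine or morpholine at the chain end, or a longer chain, would read in this assay.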